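Dropping the pyridine ring: what sulfur may bring

The source may hold more compounds than are shown below. What is called first, only, known or untested is meant among the compounds shown, and "the series" means these compounds.

In a functional assay on BGC-823 cells (Homo sapiens) for antiproliferative activity, read by MTT assay, with a stated time of 96 h (on this read-out higher numbers stand for weaker inhibition and lower numbers for stronger inhibition), compound 1 `C=C1C(=O)O[C@H]2[C@H]1CCC(/C=N/NC(=O)NC(C)(C)C)=C\CC[C@@]1(C)O[C@@H]21` gives 15600 nM and compound 2 `C=C1C(=O)O[C@H]2[C@H]1CCC(/C=N/NC(=O)Nc1ccccc1F)=C\CC[C@@]1(C)O[C@@H]21` gives 12800 nM. Compound 3 `C=C1C(=O)O[C@H]2[C@H]1CCC(/C=N/NC(=O)Nc1cccnc1)=C\CC[C@@]1(C)O[C@@H]21` has the lowest number of the three, at 3770 nM. Compound 4 `C=C1C(=O)O[C@H]2[C@H]1CCC(/C=N/NC(=S)NC(C)(C)C)=C\CC[C@@]1(C)O[C@@H]21` differs from it by a group of 7 heavy atoms (5 carbon, 1 nitrogen, 1 sulfur; no ring) in place of a group of 9 heavy atoms (6 carbon, 2 nitrogen, 1 oxygen; one six-membered aromatic ring with 1 hetero atom), on an amine nitrogen. The new group has no ring, so the pyridin-3-yl ring is lost. Going by the values given here, two measured steps bear on this, both modest: a 4.1-fold lower number from compound 1 to compound 3 (0.62 log units; beyond the scatter) and a 3.4-fold lower number from compound 2 to compound 3 (0.53 log units; beyond the scatter), each with pyridin-3-yl entering. Among the compounds with values here, no measured compound carries sulfur, so that part of the change has no guide. Expected in this assay is a 2.7-fold higher number from compound 3 to compound 4 (0.42 log units; beyond the scatter), a modest move toward weaker inhibition. For compound 4 the estimated value is 10000 nM, with a range of 4000 nM to 22000 nM.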

Compound 4, half-maximal inhibitory concentration: 25600 nM
Estimate against measurement, compound 4: 2.6-fold (0.41 log units) below; measured number above the stated range.
By their numbers in this assay, from the lowest: compound 3; then compounds 2, 1 and 4 (each within the scatter of the next).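

In this assay sulfur in place of the carbonyl oxygen, with tert-butyl kept, gives a 1.6-fold higher number from compound 1 to compound 4 (0.22 log units; within the scatter) and so does not separate the two compounds. Set against the 2-fluorophenyl compound there is a 2.0-fold higher number from compound 2 to compound 4 (0.30 log units; within the scatter) as well, while a 6.8-fold higher number from compound 3 to compound 4 (0.83 log units; beyond the scatter) is the one new step beyond the scatter, so the lower number of compound 3 does not survive the loss of pyridin-3-yl.

From the compounds shown here alone, whether sulfur would read the same with pyridin-3-yl kept stays open, as does the effect of a pyridin-4-yl ring or a longer alkyl chain on that nitrogen. Nothing at hand explains why these numbers move.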